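The source may report more compounds than this note shows. Statements on the series, on what has been measured and on what is new or still open speak of the compounds shown alone.

Compound 1 `CC1(C)CC(C)(C)c2cc(NC(=O)Nc3ccc(OC(F)(F)F)cc3)ccc2O1`: 91.5%
Compound 2 `CC1(C)CCOc2ccc(NC(=S)Nc3ccc(C(F)(F)F)cc3)cc21`: 28%
Compound 3 `CCC1(CC)CC(C)(C)Oc2ccc(NC(=S)Nc3ccc(C(F)(F)F)cc3)cc21`: 11.8%

In a functional assay on A2780 cells (Homo sapiens) for inhibition, with a stated time of 72 h, tested at 10 uM (a higher number here means more inhibition of growth at the concentration tested, a lower number less inhibition of growth), compound 2 gives 28%, the second highest of the three numbers. Compound 3 lies below it beyond the usual scatter, and compound 1 lies far above it, also beyond the scatter. Compound 4 `CC1(C)CCOc2ccc(NC(=S)Nc3ccc(OC(F)(F)F)cc3)cc21` has not yet been measured. Its difference from compound 2 is trifluoromethoxy in place of trifluoromethyl on an aromatic carbon. Going by the values given here, no step of this kind between measured compounds is known; compound 1 carries the entering group but differs from compound 2 in other places as well, so its high value is not a direct guide. The step from compound 2 to compound 4 is expected to be a modest one upward, a number 12 percentage points higher from compound 2 to compound 4 (beyond the scatter). Compound 4 is estimated at 40%, within a range from 15% to 70%.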

Compound 4, percent growth inhibition at one concentration: 16%
The estimate for compound 4 lay 24 percentage points above the measured number; measured number inside the range.
By their numbers in this assay, from the lowest: compounds 3 and 4 (each within the scatter of the next); then compound 2; then compound 1.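

In this assay, going by these compounds alone, this is the first single change that can be read on the shared core: trifluoromethoxy in place of trifluoromethyl, para to a large group, gives a number 12 percentage points lower from compound 2 to compound 4 (beyond the scatter) and so a modest loss of growth inhibition. On this core, then, trifluoromethoxy does not by itself bring high growth inhibition. No measurement offered here explains the step.

On these data alone, it remains open how a nitrile or an amine at this position would compare with compound 2 and compound 4. Also open, as far as these compounds go, is whether the same exchange would have the same effect on the core of compound 3.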